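A few compounds are considered here, and "the series" means these few. Any claim that something is new, unique, unknown or untested is made for them only; others in the source may bear on it.

Compound 1 `O=C(O)C[C@H](NC(=O)c1cncc(S(=O)(=O)NC2CC2)c1)C(=O)Oc1ccccc1`: 4300 nM
Compound 2 `CC(C)CN(CC(C)C)C(=O)c1cncc(C(=O)N[C@@H](CC(=O)O)C(=O)CSCc2ccc(F)cc2)c1`: 39000 nM

In a functional assay on NT2 cells (Homo sapiens) for inhibition (a higher number here means a weaker inhibitor, a lower number a stronger inhibitor), compound 2 has the higher of the two numbers at 39000 nM, a gap to compound 1 that lies beyond the scatter. Compound 3 `CN(C1CC1)S(=O)(=O)c1cncc(C(=O)N[C@@H](CC(=O)O)C(=O)CSCc2ccc(F)cc2)c1` has cyclopropyl(methyl)sulfamoyl in place of diisobutylcarbamoyl on an aromatic carbon. Within the data shown here, the only guide is compound 1, which also holds a cyclopropyl ring and gives 4300 nM, although it differs from compound 3 elsewhere too. The expected step of a 2.8-fold lower number from compound 2 to compound 3 (0.44 log units; beyond the scatter) runs towards a lower number and is moderate in size. For compound 3 the estimated value is 14000 nM, with an expected range of 3500 nM to 50000 nM.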

Compound 3, half-maximal inhibitory concentration: 22000 nM
Compound 3: the middle estimate sits 1.6-fold (0.20 log units) below what was measured; low and high end bracket the measured number.
By their numbers in this assay, from the lowest: compound 1; then compounds 3 and 2 (each within the scatter of the next).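

In this assay, the step of a 1.8-fold lower number from compound 2 to compound 3 (0.25 log units; within the scatter) shows that this aromatic carbon, two atoms from the ring nitrogen, accepts cyclopropyl(methyl)sulfamoyl in place of diisobutylcarbamoyl with no change beyond the scatter. A group carrying a three-membered ring and a sulfur atom therefore reads the same here as the open-chain amide. Nothing measured gives a reason for this result. As far as these compounds go, what remains open is whether a much smaller group at this carbon, such as an amine or a carboxylic acid, would move the number beyond the scatter.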